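Swapping amino for triazolyl on a weak cytotoxic compound

The source may report more compounds than this note shows. Statements on the series, on what has been measured and on what is new or still open speak of the compounds shown alone.

Compound 1 `Clc1nc(-n2cncn2)c2sccc2n1`: > 250000 nM
Compound 2 `Nc1nc(Cl)nc2c(Br)csc12`: 150000 nM

Among the compounds with values here, in a functional assay on L1210 cells (Mus musculus) for cytotoxicity, read by cell counting, with a stated time of 48 h (on this read-out higher numbers stand for weaker inhibition and lower numbers for stronger inhibition), compound 2 gives 150000 nM, the only exact number so far. Compound 1 reads > 250000 nM, and that value is a limit of the assay, not a number.

The next compound to be tested is compound 3 `Clc1nc(-n2cncn2)c2scc(Br)c2n1`. It has 1H-1,2,4-triazol-1-yl in place of amino on an aromatic carbon, next to the ring nitrogen of compound 2: 1H-1,2,4-triazol-1-yl in place of amino on an aromatic carbon. The new group is already present in compound 1, while compound 3 keeps the bromo group of compound 2, which compound 1 lacks. These two compounds differ in more than one place, so they offer no clean comparison, and the size of the step in this assay remains uncertain.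

A modest move toward stronger inhibition is expected, estimated as a 2.5-fold lower number from compound 2 to compound 3 (0.40 log units; beyond the scatter), although the step could also vanish or reverse. For compound 3 the estimated value is 60000 nM, with an expected range from 6000 nM to 250000 nM.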

Compound 3, half-maximal inhibitory concentration: 157000 nM
For compound 3 the middle estimate is 2.6-fold (0.42 log units) below the measured one; the range from low to high includes it.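

In this assay, the swap of amino for 1H-1,2,4-triazol-1-yl on the aromatic carbon next to the ring nitrogen comes to a 1.0-fold higher number from compound 2 to compound 3 (0.02 log units; within the scatter), so the two compounds read alike. Within the data shown here, this is the first clean look at this position, and it shows that a group with a five-membered aromatic ring and no hydrogen-bond donor can stand where amino stood without any shift beyond the scatter, although both compounds remain weak in this assay. The other single change, bromo in place of hydrogen on an aromatic carbon, comes to an at least 1.5-fold lower number from compound 1 to compound 3 (0.20 log units; that floor lies within the scatter), and no gain from bromo can be claimed because the starting point of this step is a limit of the assay, not a number: the limit of > 250000 nM in this assay, at which 1 of the 3 values shown sits.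

From the compounds shown here alone, two groups that read alike do not show whether anything at this position can move the number, so the effect of a methoxy group or a morpholine ring there remains open. Going by these compounds, how much bromo counts when amino holds this position also remains open.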